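Removing the Hydroxy Group from Compound 2

The source may hold more compounds than are shown below. What is called first, only, known or untested is meant among the compounds shown, and "the series" means these compounds.

Of the compounds shown here, three have been measured in a functional assay on HEK293 cells for agonist activity at D(4) dopamine receptor (Homo sapiens), read by FLIPR; on this read-out lower numbers stand for an effect already at smaller amounts and higher numbers for an effect only at larger amounts of compound. Compound 1 `Cc1cc(C)cc(NC(=O)CN2CCC(c3cccc[n+]3[O-])CC2)c1` gives 52 nM in this assay. Compound 2 `Cc1cccc(NC(=O)CN2CCC(c3ccc(O)cc3)CC2)c1` gives 70 nM, and compound 3 `Cc1cc(C(=O)NCN2CCC(c3cccc[n+]3[O-])CC2)ccc1F` gives 50 nM. Compound 2 carries the highest number of the three, yet its distance to compound 1 and its distance to compound 3 both lie within the usual scatter of repeated measurements, so the three values cannot be told apart on this evidence.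

Compound 4 `Cc1cccc(NC(=O)CN2CCC(c3ccccc3)CC2)c1` has not yet been measured. It differs from compound 2 in one place: hydrogen in place of hydroxy on an aromatic carbon. Within the data shown here, no pair of measured compounds shows this particular change, so nothing in the recorded values tells how the loss of the hydroxy group acts in this assay.

The account therefore rests on the value of compound 2 alone, 70 nM, and on the small size of the change, a single heavy atom. The step from the measured value to the estimate is expected to be modest, a 1.6-fold higher number from compound 2 to compound 4 (0.20 log units; within the scatter), with a slight lean toward a higher number. Compound 4 is expected to give about 110 nM in this assay, within a range from 35 nM to 350 nM.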

Compound 4, half-maximal effective concentration: 170 nM
Compound 4: the middle estimate sits 1.5-fold (0.19 log units) below what was measured, within the range that was stated.
By their numbers in this assay, from the lowest: compounds 3, 1 and 2 (each within the scatter of the next); then compound 4.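

The measured pair shows that this place on the aromatic ring is not indifferent in this assay: the change from 4-hydroxyphenyl to phenyl, with hydrogen in place of hydroxy on an aromatic carbon, brings a 2.4-fold higher number from compound 2 to compound 4 (0.39 log units; beyond the scatter) and gives the series its first difference beyond the scatter. The earlier compounds shown here could not show this, since their values could not be told apart and no two of them differed in one place only. This is still a single step on a single core, and nothing available here explains why the number rises when the hydroxy group leaves.

Going by these compounds, it remains open whether the hydroxy group itself matters or whether other groups on the same carbon would keep the lower number, as a methoxy group, an amine or a fluorine atom there could show. It is also open whether the same change would give a similar step on the cores of compound 1 and compound 3, where no such pair is shown.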